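Amide tail variation in a flavonol series: growth inhibition

The source may report more compounds than this note shows. Statements on the series, on what has been measured and on what is new or still open speak of the compounds shown alone.

Measured compounds:
compound 1 `COc1ccc(-c2oc3c(OC)c(OC)cc(OCCCC(=O)NCc4ccccn4)c3c(=O)c2O)cc1` — > 40000 nM
compound 2 `COc1ccc(-c2oc3c(OC)c(OC)cc(OCCCC(=O)N4CCN(C)CC4)c3c(=O)c2O)cc1` — > 40000 nM
compound 3 `COc1ccc(-c2oc3c(OC)c(OC)cc(OCCCCC(=O)NCc4ccccn4)c3c(=O)c2O)cc1` — > 40000 nM

In a functional assay on FaDu cells (Homo sapiens) for antiproliferative activity, read by sulforhodamine B assay, with a stated time of 48 h (on this read-out lower numbers stand for stronger inhibition and higher numbers for weaker inhibition), compound 1 gives > 40000 nM, which is a limit of the assay and not a number. Compound 2 gives > 40000 nM, again a limit. Compound 3 gives > 40000 nM, also a limit. The change from compound 1 to compound 2 is 4-methylpiperazin-1-yl in place of ((pyridin-2-yl)methyl)amino on a carbonyl carbon, and its step, a step that the two limits leave unreadable from compound 1 to compound 2, cannot be sized from two limits. The two cores differ by (((pyridin-2-yl)methyl)carbamoyl)methyl in place of ((pyridin-2-yl)methyl)carbamoyl on a saturated chain carbon, three bonds along the chain from an oxygen on an aromatic ring.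

Compound 4 `COc1ccc(-c2oc3c(OC)c(OC)cc(OCCCCC(=O)N4CCN(C)CC4)c3c(=O)c2O)cc1` is not yet measured. It arises from compound 3 by 4-methylpiperazin-1-yl in place of ((pyridin-2-yl)methyl)amino on a carbonyl carbon, the same change as from compound 1 to compound 2, since the place reads the same in both. With every value shown sitting at the limit of > 40000 nM in this assay, at which 3 of the 3 values shown sit, the step from compound 3 to compound 4 is expected to be unreadable in the same way, a step that the limit leaves unreadable from compound 3 to compound 4, resting on a step that the two limits leave unreadable from compound 1 to compound 2 and (the limit of > 40000 nM in this assay, at which 3 of the 3 values shown sit). For compound 4 in this assay the estimate is 80000 nM, most likely again reported as a limit only.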

Compound 4, half-maximal inhibitory concentration: > 40000 nM
Compound 4: a limit, no number (the forecaster's own chance of this, stated with the estimate: 85%); the middle value is on the limit's open side.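

No new step can be read from compound 1, compound 2 or compound 3 to compound 4 in this assay, since all four results are limits and not numbers: the limit of > 40000 nM in this assay, at which 4 of the 4 values shown sit.

The compounds shown leave open whether either the amide tail or the chain length has any effect on growth inhibition in this assay.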